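The source may report more compounds than this note shows. Statements on the series, on what has been measured and on what is new or still open speak of the compounds shown alone.

Measured in a functional assay on PC-3 cells (Homo sapiens) for cytotoxicity, read by sulforhodamine B assay, with a stated time of 48 h; on this read-out lower numbers stand for stronger inhibition and higher numbers for weaker inhibition:
- Compound 1 `C[C@H]1CC[C@@H]2[C@@H](OC(=O)[C@]23CC(c2ccccc2[N+](=O)[O-])=NO3)[C@]2(C)C(=O)C=C[C@@]12O`: 37000 nM
- Compound 2 `C[C@H]1CC[C@@H]2[C@@H](OC(=O)[C@]23CC(c2ccc([N+](=O)[O-])cc2)=NO3)[C@]2(C)C(=O)C=C[C@@]12O`: 12000 nM
- Compound 3 `COc1cc(C2=NO[C@]3(C2)C(=O)O[C@@H]2[C@H]3CC[C@H](C)[C@]3(O)C=CC(=O)[C@@]23C)ccc1O`: 16000 nM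

Compound 3 gives 16000 nM. Its nearest neighbour is separated by a 1.3-fold higher number from compound 2 to compound 3 (0.12 log units; within the scatter), while the furthest gap is a 2.3-fold lower number from compound 1 to compound 3 (0.36 log units; beyond the scatter).

Compound 4 `Cc1ccc(C2=NO[C@]3(C2)C(=O)O[C@@H]2[C@H]3CC[C@H](C)[C@]3(O)C=CC(=O)[C@@]23C)cc1` has not yet been measured. It puts 4-methylphenyl in place of 4-hydroxy-3-methoxyphenyl on a carbon with a double bond to nitrogen.

For the measured compounds named here, the closest precedent is the exchange of one such group for another, a 1.3-fold higher number from compound 2 to compound 3 (0.12 log units; within the scatter). The larger measured steps, a 3.1-fold lower number from compound 1 to compound 2 (0.49 log units; beyond the scatter) and a 2.3-fold lower number from compound 1 to compound 3 (0.36 log units; beyond the scatter), both start from 2-nitrophenyl, which plays no part here. In this assay, no step beyond the scatter is therefore expected. The expected change is a 1.1-fold lower number from compound 3 to compound 4 (0.03 log units; within the scatter). The estimate for compound 4 is 15000 nM, with an expected range from 7000 nM to 32000 nM.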

Compound 4, half-maximal inhibitory concentration: 14000 nM
Compound 4: middle estimate off by 1.1-fold (0.03 log units), on the high side; the range from low to high includes it.
By their numbers in this assay, from the lowest: compounds 2, 4 and 3 (each within the scatter of the next); then compound 1.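

In this assay, 4-methylphenyl, with no hydrogen-bond donors or acceptors, replaces 4-hydroxy-3-methoxyphenyl with a 1.1-fold lower number from compound 3 to compound 4 (0.06 log units; within the scatter), and methyl in place of nitro on an aromatic carbon gives a 1.2-fold higher number from compound 2 to compound 4 (0.07 log units; within the scatter), so neither the hydroxy and methoxy groups nor the nitro group are needed to hold this level. Only the 2-nitrophenyl group stands apart, with a 2.6-fold lower number from compound 1 to compound 4 (0.42 log units; beyond the scatter). No measurement shown accounts for these results.

The compounds shown leave open whether an amine or a carboxylic acid on the aromatic ring, or a longer chain in place of methyl, would move the number beyond the scatter.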